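Swapping 4-Fluorobenzyl for 3-Hydroxypropyl

A few compounds are considered here, and "the series" means these few. Any claim that something is new, unique, unknown or untested is made for them only; others in the source may bear on it.

Of the compounds shown here, three sharing one core have been measured in a functional assay on RAW264.7 cells (Mus musculus) for inhibition, read by Griess assay, with stated times of 2 h and 24 h; a higher number here means a weaker inhibitor, a lower number a stronger inhibitor. Compound 1 `COc1ccc([C@@H]2CC(=O)c3c(O)cc(OCc4cn(Cc5ccccc5C#N)nn4)cc3O2)cc1O` gives 14600 nM, compound 2 `COc1ccc([C@@H]2CC(=O)c3c(O)cc(OCc4cn(Cc5ccccc5Cl)nn4)cc3O2)cc1O` gives 6140 nM, and compound 3 `COc1ccc([C@@H]2CC(=O)c3c(O)cc(OCc4cn(Cc5ccc(F)cc5)nn4)cc3O2)cc1O` gives 15100 nM. Compound 3 thus stands level with compound 1 within the scatter, at the upper end of these numbers, and clear of compound 2.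

Compound 4 `COc1ccc([C@@H]2CC(=O)c3c(O)cc(OCc4cn(CCCO)nn4)cc3O2)cc1O` differs from compound 3 in one place: 2-hydroxyethyl in place of 4-fluorophenyl on a saturated chain carbon bound to an aromatic nitrogen. Cut one bond further out, 3-hydroxypropyl replaces 4-fluorobenzyl.

The measured steps bear on this only indirectly. The step of a 2.5-fold higher number from compound 2 to compound 3 (0.39 log units; beyond the scatter) is modest, as is the step of a 2.4-fold lower number from compound 1 to compound 2 (0.38 log units; beyond the scatter), while the step of a 1.0-fold higher number from compound 1 to compound 3 (0.01 log units; within the scatter) stays within the scatter. Among the compounds with values here, all three compounds keep an aromatic ring in this region, so no measured step shows what losing it does. No step beyond the scatter can therefore be firmly expected, only a slight lean towards a higher number.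

The expected change is a 1.5-fold higher number from compound 3 to compound 4 (0.16 log units; within the scatter). For compound 4 the estimate is 22000 nM, with an expected range of 8000 nM to 60000 nM.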

Compound 4, half-maximal inhibitory concentration: 16700 nM
For compound 4 the middle estimate is 1.3-fold (0.12 log units) above the measured one, and the stated range covers the measured number.
By their numbers in this assay, from the lowest: compound 2; then compounds 1, 3 and 4 (each within the scatter of the next).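

In this assay, the aromatic ring at this place proves dispensable for holding the level of compounds 1 and 3: with 3-hydroxypropyl in place of 4-fluorobenzyl, the readings stay within the scatter (a 1.1-fold higher number from compound 3 to compound 4 (0.04 log units; within the scatter)) and (a 1.1-fold higher number from compound 1 to compound 4 (0.06 log units; within the scatter)). Compound 2 goes against this, as the 2-chlorophenyl group remains the one clear outlier among the four (a 2.7-fold higher number from compound 2 to compound 4 (0.43 log units; beyond the scatter)), so a ring-free chain matches the 2-cyanophenyl and 4-fluorophenyl compounds but not the 2-chlorophenyl one. Nothing available explains these readings. The compounds shown leave open how a plain propyl chain, an amine or a carboxylic acid would read at this place, and so whether the hydroxyl of the 3-hydroxypropyl group matters at all. They also leave open whether a longer chain would stay level with compound 4.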